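Swapping Chloro for tert-Butyl on the Benzyl Ring

The source may hold more compounds than are shown below. What is called first, only, known or untested is meant among the compounds shown, and "the series" means these compounds.

Compound 1 `C=C(Br)C(=O)Nc1cccc(/C=C2\SC(=O)N(Cc3ccc(Cl)cc3)C2=O)c1` was tested in a functional assay on CCRF-CEM cells (Homo sapiens) for cytotoxicity, read by cell counting, with a stated time of 3 days (a higher number here means a weaker inhibitor, a lower number a stronger inhibitor), and gave 1400 nM. Among the numbers shown it stands lowest of two; its nearest neighbour, compound 2 `CCN1C(=O)S/C(=C\c2ccc(N)cc2)C1=O`, gives 91000 nM in this assay. Compound 3 `Nc1cccc(/C=C2\SC(=O)N(Cc3ccc(Cl)cc3)C2=O)c1` reaches only a limit of the assay, > 250000 nM in this assay, namely (the limit of > 250000 nM in this assay, at which 1 of the 3 values shown sits). Within the data shown here, the single step between measured compounds is an at least 170-fold higher number from compound 1 to compound 3 (2.25 log units; beyond the scatter).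

Compound 4 `C=C(Br)C(=O)Nc1cccc(/C=C2\SC(=O)N(Cc3ccc(C(C)(C)C)cc3)C2=O)c1` has not yet been measured and differs from compound 1 as follows: tert-butyl in place of chloro on an aromatic carbon. Among the measured compounds shown here, no measured step touches the 4-chlorophenyl to 4-(tert-butyl)phenyl change; the only one available, an at least 170-fold higher number from compound 1 to compound 3 (2.25 log units; beyond the scatter), concerns the (1-bromoethenyl)carbonyl group, which compound 4 keeps intact. With nothing bearing on the change, compound 4 is expected to show a step of no change at the digits printed from compound 1 to compound 4 (within the scatter), that is, none beyond the scatter. Compound 4 is therefore estimated at 1400 nM, between 450 nM and 4500 nM in this assay.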

Compound 4, half-maximal inhibitory concentration: 3000 nM
For compound 4 the middle estimate is 2.1-fold (0.33 log units) below the measured one, within the range that was stated.
By their numbers in this assay, from the lowest: compound 1; then compound 4; then compound 2. At a limit, above all of these: compound 3.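

Among these compounds, the change from 4-chlorophenyl to 4-(tert-butyl)phenyl gives a 2.1-fold higher number from compound 1 to compound 4 (0.33 log units; beyond the scatter) in this assay and is the first reading at this position, since the earlier step concerned only the (1-bromoethenyl)carbonyl group. The step is modest, so with that group kept intact, this position accepts tert-butyl in place of chloro at a small cost in this cell-based read-out, though this single pair sets no trend. Nothing among the data shown accounts for the size of this step.

On these data alone, whether an amine, a carboxylic acid or a methoxy group on the same aromatic carbon would fall near chloro, near tert-butyl or elsewhere remains open. So does the effect of a longer chain in place of the benzyl group on the core of compound 1.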